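Lactone amide chalcones: bromophenyl step from compound 2

The source may report more compounds than this note shows. Statements on the series, on what has been measured and on what is new or still open speak of the compounds shown alone.

Compound 1 `O=C(COc1ccc(C(=O)/C=C/c2ccccc2Cl)cc1)N[C@H]1CCOC1=O`: in a functional assay on MCF7 cells (Homo sapiens) for antiproliferative activity, read by MTT assay, with a stated time of 72 h (on this read-out higher numbers stand for weaker inhibition and lower numbers for stronger inhibition), compound 1 gives 17400 nM.
Compound 2 `COc1ccccc1/C=C/C(=O)c1ccc(OCC(=O)N[C@H]2CCOC2=O)cc1`: in this assay compound 2 sits at the limit, > 64000 nM.
Compound 3 `O=C(CNc1ccc(Cl)cc1Cl)N[C@H]1CCOC1=O`: in this assay compound 3 likewise sits at the limit, > 64000 nM.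

Compound 2 therefore stands at the limit of this assay, with compound 3; only compound 1 gives a number. Within the data shown here, the one measured step that bears on the change is an at least 3.6-fold higher number from compound 1 to compound 2 (0.56 log units; beyond the scatter), whose size is capped by the limit of > 64000 nM in this assay, at which 2 of the 3 values shown sit. Compound 4 `O=C(COc1ccc(C(=O)/C=C/c2cccc(Br)c2)cc1)N[C@H]1CCOC1=O` differs from compound 2 by 3-bromophenyl in place of 2-methoxyphenyl on a double-bonded chain carbon bound to a double-bonded chain carbon. This takes out the methoxy and brings a halogen back onto the ring, as in compound 1, though bromo rather than chloro. A step back toward compound 1 is expected in this assay. Compound 4 is estimated at 22000 nM, with a range of 7000 nM to 64000 nM, which means an expected at least 2.9-fold lower number from compound 2 to compound 4 (0.46 log units; beyond the scatter).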

Compound 4, half-maximal inhibitory concentration: 28300 nM
Estimate against measurement, compound 4: 1.3-fold (0.11 log units) below, and the stated range covers the measured number.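

At this place in this assay, 3-bromophenyl in place of 2-methoxyphenyl gives a measured number, an at least 2.2-fold lower number from compound 2 to compound 4 (0.35 log units; beyond the scatter), and the true size of this step stays unknown because one end is a limit: the limit of > 64000 nM in this assay, at which 2 of the 4 values shown sit.

Against 2-chlorophenyl, the same place gives a 1.6-fold higher number from compound 1 to compound 4 (0.21 log units; within the scatter), so 3-bromophenyl and 2-chlorophenyl cannot be told apart here. Among these three compounds, only the methoxy-bearing ring sits at the limit.

Still open, on these data alone, is whether the halogen itself or its place on the ring matters, and how an amine or a carboxylic acid on this phenyl would read.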